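A few compounds are considered here, and "the series" means these few. Any claim that something is new, unique, unknown or untested is made for them only; others in the source may bear on it.

Three compounds of the series carry a measurement in a functional assay on K562 cells (Homo sapiens) for inhibition, read by MTT assay, with a stated time of 72 h; a higher number here means a weaker inhibitor, a lower number a stronger inhibitor. Compound 1 `COc1ccc(-n2cc(-c3ccc(C)c(Nc4nccc(-c5cccnc5)n4)c3)nn2)cc1` gives only a limit of the assay, > 30000 nM. Compound 2 `Cc1ccc(-n2cc(-c3cc(C(F)(F)F)cc(C(F)(F)F)c3)nn2)cc1Nc1nccc(-c2cccnc2)n1` gives 2650 nM. Compound 3 `Cc1ccc(-c2nnc(-c3ccc(CN4CCN(C)CC4)cc3)o2)cc1Nc1nccc(-c2cccnc2)n1` gives 4900 nM, the higher of the two numbers shown, though its gap to compound 2 lies within the scatter. Compound 4 `Cc1ccc(-c2nnc(-c3ccc(CN4CCN(C)CC4)c(C(F)(F)F)c3)o2)cc1Nc1nccc(-c2cccnc2)n1` differs from compound 3 by trifluoromethyl in place of hydrogen on an aromatic carbon, a trifluoromethyl in place of hydrogen on an aromatic carbon. Among the measured compounds shown here, no step between measured compounds shows how such a change moves the read-out in this assay, so no shift beyond the scatter is assumed in either direction. For compound 4 the expected value in this assay is 4000 nM, within 1500 nM to 12000 nM. The expected step is estimated at a 1.2-fold lower number from compound 3 to compound 4 (0.09 log units; within the scatter), within the scatter.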

Compound 4, half-maximal inhibitory concentration: 510 nM
Compound 4: middle estimate off by 7.8-fold (0.89 log units), on the high side; measured number outside the range, below it.
By their numbers in this assay, from the lowest: compound 4; then compounds 2 and 3 (each within the scatter of the next). At a limit, above all of these: compound 1.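

Among the compounds shown here, on an aromatic carbon ortho to a (4-methylpiperazin-1-yl)methyl group, trifluoromethyl in place of hydrogen gives a 9.6-fold lower number from compound 3 to compound 4 (0.98 log units; beyond the scatter) in this assay as the only one-place step so far. For the compounds shown here, this position therefore responds to substitution; compounds 1 to 3 could not show this, as no pair among them differs in one place. No measurement shown accounts for the size of this step.

Whether the step is specific to trifluoromethyl remains open: a chlorine, a methyl or a methoxy group on this carbon is not among the compounds shown.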